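Propyl to 4-Fluorophenyl on the Ring Amine of Compound 3

The compounds below may be only part of what the source reports. "The series", "measured", "known", "first", "only" and "open" are said of these compounds alone.

The three measured compounds, all tested in an in vitro assay on HEK-tsA201 cells for antagonist activity at Neuronal acetylcholine receptor; alpha3/beta4 (Homo sapiens), read by fluorescence and calcium flux; on this read-out higher numbers stand for weaker inhibition and lower numbers for stronger inhibition:
compound 1, `CCOc1ccc(C(=O)Nc2cc(C)cc(C)n2)cc1`, gives 17400 nM
compound 2, `C=CCOc1ccc(C(=O)Nc2cccc(Br)n2)cc1`, gives 65500 nM
compound 3, `CCCNc1cccc(NC(=O)c2ccc(OCCC)cc2)n1`, gives 12600 nM

Compound 3 holds the lowest of the three numbers in this assay. Its nearest neighbour is compound 1, whose number lies slightly higher, a gap that falls within the scatter of repeated measurements, so the two cannot be ordered. Compound 2 stands furthest away, with a number clearly higher than that of compound 3, a gap that lies beyond the scatter.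

Compound 4, `CCCOc1ccc(C(=O)Nc2cccc(Nc3ccc(F)cc3)n2)cc1`, has not yet been measured in this assay. It differs from compound 3 in one place: 4-fluorophenyl in place of propyl on a nitrogen on an aromatic ring. Among the compounds with values here, no measured pair among the three shows this kind of change, so nothing in the data fixes the size or direction of its effect.

Given that absence, the step from compound 3 to compound 4 in this assay is expected to be small, a 1.6-fold lower number from compound 3 to compound 4 (0.20 log units; within the scatter), and may well fall within the scatter. Compound 4 is accordingly estimated at 8000 nM, with a plausible range from 2500 nM to 25000 nM.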

Compound 4, half-maximal inhibitory concentration: > 100000 nM
Compound 4: a limit, no number; the forecaster's own chance of this, stated with the estimate: 10%; middle value at least 12-fold (1.09 log units) away from the limit.
By their numbers in this assay, from the lowest: compounds 3 and 1 (each within the scatter of the next); then compound 2. At a limit, above all of these: compound 4.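

In this assay, this is the first change among the compounds shown that can be read at a single place, and it shows that the group on this nitrogen matters: 4-fluorophenyl in place of propyl gives an at least 7.9-fold higher number from compound 3 to compound 4 (0.89 log units; beyond the scatter). Compound 4 carries a limit of the assay and not a number, so the step has a lower bound but no known size: the limit of > 100000 nM in this assay, at which 1 of the 4 values shown sits. Among the compounds shown, then, the propylamino group of compound 3 is compatible with measurable inhibition in this assay, whereas the (4-fluorophenyl)amino group of compound 4 takes the read-out to that limit.

The compounds shown leave open whether the loss follows from the aromatic ring itself, from the fluorine on it or from the larger group as a whole, since this single change alters all three at once. A plain phenyl, a cyclohexyl ring or a butyl chain on the same nitrogen would separate these readings, and an unsubstituted amine would show what the propyl group of compound 3 contributes.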